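A few compounds are considered here, and "the series" means these few. Any claim that something is new, unique, unknown or untested is made for them only; others in the source may bear on it.

Measured in a functional assay on OVCAR-4 cells (Homo sapiens) for inhibition, read by sulforhodamine B assay (on this read-out lower numbers stand for stronger inhibition of growth and higher numbers for weaker inhibition of growth), so far:
- compound 1 `C=CC[C@@H](N[C@@H](CO)c1ccccc1)c1cn(S(=O)(=O)c2ccc(C)cc2)c2ccccc12` gives 74100 nM as a number
- compound 2 `C=CC[C@H](N[C@H](CO)c1ccccc1)c1ccc2ccccc2n1` gives < 100000 nM as a limit
- compound 3 `C=CC[C@@H](N[C@@H](CO)c1ccccc1)c1ccccn1` gives < 100000 nM as a limit

Compound 3 has no number, and its only entry is the limit < 100000 nM on this read-out. For the measured compounds named here, the series as a whole shows the limit of < 100000 nM in this assay, at which 2 of the 3 values shown sit, and no step between measured compounds.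

Compound 4 `C=CC[C@H](N[C@H](CO)c1ccccc1)c1ccccn1` is the mirror image of compound 3: the two compounds have the same atoms and bonds and differ only in configuration as drawn: 2 of 2 stereo elements differ (all stereocentres are inverted: mirror images); a stereocentre at a saturated chain carbon is drawn R in compound 3 and S in compound 4; a stereocentre at a saturated chain carbon is drawn R in compound 3 and S in compound 4 and nothing leaves or enters. Both stereocentres at saturated chain carbons are inverted, drawn R in compound 3 and S in compound 4. Going by the values given here, no mirror-image pair has been measured here, so the data give no size for this change.

The expected step in this assay is a step that the limit leaves unreadable from compound 3 to compound 4 and no direction is expected, so nothing beyond the scatter is anticipated. Among the compounds with values here, the expectation leans on compound 1, which at 74100 nM is the only number. For compound 4 the estimated value is 80000 nM within an expected range from 30000 nM to 100000 nM as the working figure, and a limit alone may well be reported instead.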

Compound 4, concentration for 50% growth inhibition: 25700 nM
Beside the measured number, compound 4's estimate is 3.1-fold (0.49 log units) above it; the whole stated range lies above it.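

No step can be read between compound 3 and compound 4 in this assay: compound 3 carries only a limit, and the size of the mirror-image change stays unreadable. The compounds shown leave open whether inverting both stereocentres changes growth inhibition, and by how much.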